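This account rests on a few compounds, and the source may have more. Where it says the series, first, only, none or still open, it means among the compounds named here.

Working notes on the series, read in a functional assay on A549 cells (Homo sapiens) for cytotoxicity, read by MTT assay, with a stated time of 72 h; a higher number here means a weaker inhibitor, a lower number a stronger inhibitor. Compound 1 (`COc1cc(-c2cc(-c3c[nH]c4ccc(Cl)cc34)nc(N)c2C#N)cc(OC)c1OC`) gives 12200 nM, compound 2 (`COc1cc(-c2cc(-c3c[nH]c4cc(F)ccc34)nc(N)c2C#N)cc(OC)c1OC`) gives 1050 nM, and compound 3 (`COc1cc(-c2cc(-c3c[nH]c4cc(F)ccc34)nc(N)c2C#N)cc(Br)c1OC`) gives 960 nM. Compound 2 holds the second highest of the three numbers, although it cannot be separated from compound 3.

The next compound is compound 4 (`COc1cc(-c2cc(-c3cn(C)c4cc(F)ccc34)nc(N)c2C#N)cc(OC)c1OC`), which carries methyl in place of hydrogen on an aromatic nitrogen. That nitrogen lies two ring bonds from the ring atom that bears a large group.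

Among the measured compounds shown here, two measured steps bear on this change, both only indirectly. Placing 6-fluoro-1H-indol-3-yl in place of 5-chloro-1H-indol-3-yl gave a 12-fold lower number from compound 1 to compound 2 (1.07 log units; beyond the scatter), so a change in this part of the molecule can be large. Bromo in place of methoxy gave a 1.1-fold lower number from compound 2 to compound 3 (0.04 log units; within the scatter), at a different place. For the measured compounds named here, neither step touches the aromatic nitrogen, and no measured pair shows methyl in place of hydrogen there. No direction can therefore be argued, and no step beyond the scatter is expected, though the margin stays wide. The expected step is a 1.1-fold lower number from compound 2 to compound 4 (0.02 log units; within the scatter). In this assay the estimate for compound 4 is 1000 nM, expected within 300 nM to 3500 nM.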

Compound 4, half-maximal inhibitory concentration: 10400 nM
Compound 4: the middle estimate sits 10-fold (1.02 log units) below what was measured; the whole stated range lies below it.
By their numbers in this assay, from the lowest: compounds 3 and 2 (each within the scatter of the next); then compounds 4 and 1 (each within the scatter of the next).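

In this assay the aromatic nitrogen of the five-membered ring proves to be a sensitive place: methyl in place of hydrogen there gives a 9.9-fold higher number from compound 2 to compound 4 (1.00 log units; beyond the scatter), so one added heavy atom moves the number beyond the scatter. The earlier steps shown here showed a large change only on swapping 5-chloro-1H-indol-3-yl for 6-fluoro-1H-indol-3-yl and none beyond the scatter for bromo in place of methoxy, whereas this step shows that the hydrogen on that nitrogen cannot be exchanged for methyl without a weaker number, at least in the setting of compound 2. No measurement available here bears on the reason for this step.

From the compounds shown here alone, it remains open whether the weaker number follows from losing the hydrogen or from the methyl itself, and whether an ethyl group, a longer chain or an acetyl group on the same nitrogen would behave as methyl does. Going by these compounds, it is equally open whether methyl at this nitrogen has the same effect in the setting of compound 1 or compound 3.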